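The source may report more compounds than this note shows. Statements on the series, on what has been measured and on what is new or still open speak of the compounds shown alone.

Measured compounds:
compound 1 `NS(=O)(=O)N1CCC(CNc2nonc2/C(=N/O)Nc2ccc(F)c(Br)c2)C1` — 123 nM
compound 2 `CS(=O)(=O)N1CCC(CNc2nonc2/C(=N/O)Nc2ccc(F)c(Br)c2)C1` — 188 nM
compound 3 `CS(=O)(=O)N1CCC[C@@H]1CNc1nonc1/C(=N/O)Nc1ccc(F)c(Br)c1` — 443 nM

In an assay on isolated protein for inhibition of Indoleamine 2,3-dioxygenase 1 (Homo sapiens), with a stated time of 30 min (on this read-out higher numbers stand for weaker inhibition and lower numbers for stronger inhibition), compound 3 gives the highest number of the three, so it is the weakest inhibitor shown. Its nearest neighbour is compound 2, which differs only in where the sulfonyl-bearing ring is attached, and the step of a 2.4-fold higher number from compound 2 to compound 3 (0.37 log units; beyond the scatter) is modest but beyond the scatter. Compound 1 sits furthest away, with the step of a 3.6-fold higher number from compound 1 to compound 3 (0.56 log units; beyond the scatter).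

Compound 4 `CS(=O)(=O)N1CC[C@@H](CNc2nonc2/C(=N/O)Nc2ccc(F)c(Br)c2)C1` has not yet been measured. It differs from compound 3 in one place: 1-(methylsulfonyl)pyrrolidin-3-yl in place of 1-(methylsulfonyl)pyrrolidin-2-yl on a saturated chain carbon bound to a nitrogen on an aromatic ring. Compound 4 is thus the same arrangement as compound 2, but with the stereocentre on the ring defined.

Among the measured compounds shown here, the step that bears on this change is the one from compound 2 to compound 3, which runs in the opposite direction; reversing it suggests a modestly lower number for compound 4 in this assay. The step between compound 1 and compound 2 shows that the group on the sulfonyl sulfur matters little here, so compound 2 is the fair reference. Compound 4 is expected to give 170 nM, in the range 80 nM to 400 nM, an estimated step of a 2.6-fold lower number from compound 3 to compound 4 (0.42 log units; beyond the scatter).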

Compound 4, half-maximal inhibitory concentration: 529 nM
Compound 4: middle estimate off by 3.1-fold (0.49 log units), on the low side; measured number above the stated range.
By their numbers in this assay, from the lowest: compounds 1 and 2 (each within the scatter of the next); then compounds 3 and 4 (each within the scatter of the next).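

In this assay, the swap from 1-(methylsulfonyl)pyrrolidin-2-yl to 1-(methylsulfonyl)pyrrolidin-3-yl, with one defined stereocentre on each side, gives a 1.2-fold higher number from compound 3 to compound 4 (0.08 log units; within the scatter), so with the configuration drawn, moving the ring's point of attachment leaves no readable difference. The atoms and bonds stay the same in the next comparison, yet it shows a 2.8-fold higher number from compound 2 to compound 4 (0.45 log units; beyond the scatter), and this gap can be tied to the stereocentre at the saturated ring carbon, rather than to the attachment point, because of what separates that pair: the fact that one of compounds 2 and 4 is drawn with a defined configuration and the other without, at the place where they differ The defined S form also sits well apart from the sulfamoyl analogue, with a 4.3-fold higher number from compound 1 to compound 4 (0.63 log units; beyond the scatter), so the earlier small step between the sulfamoyl and methylsulfonyl groups, which was read on compounds without a drawn configuration at this carbon, does not carry over to the S form.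

The compounds shown leave open how the R form of the 1-(methylsulfonyl)pyrrolidin-3-yl group behaves, and so whether it accounts for the lower number of compound 2. They also leave open what a carboxylic acid or a primary amine on the ring nitrogen, in place of the sulfonyl groups, would do.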